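Adding an Isobutylcarbonyl Group to an Inactive Amide

This account rests on a few compounds, and the source may have more. Where it says the series, first, only, none or still open, it means among the compounds named here.

Compound 1 `CC(C)CC(=O)NC(=O)c1c[nH]c([C@@H](O)c2ccccc2)cc1=O`: in a functional assay on K562 cells (Homo sapiens) for inhibition, read by sulforhodamine B assay, with a stated time of 48 h (a higher number here means a weaker inhibitor, a lower number a stronger inhibitor), compound 1 gives > 50000 nM, which is a limit of the assay rather than a number.
Compound 2 `NC(=O)c1cn(CCO)c([C@@H](O)c2ccccc2)cc1=O`: in this assay compound 2 gives > 50000 nM, again only a limit.
Compound 3 `CC(=O)O[C@@H](c1ccccc1)c1cc(=O)c(C(N)=O)cn1CCO`: in this assay compound 3 gives > 50000 nM, once more a limit.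

Compound 2 therefore stands at the ceiling of what this assay can report, and so does every other compound shown; all three values sit at the same limit (the limit of > 50000 nM in this assay, at which 3 of the 3 values shown sit). Among the compounds with values here, the only measured step, a step that the two limits leave unreadable from compound 2 to compound 3, cannot be sized for that reason.

Compound 4 `CC(C)CC(=O)NC(=O)c1cn(CCO)c([C@@H](O)c2ccccc2)cc1=O` differs from compound 2 by isobutylcarbonyl in place of hydrogen on an amide-type nitrogen. Within the data shown here, no measured step reads on this change. Compound 1 already carries the same isobutylcarbonyl group on its amide nitrogen, and compound 1 stays at the limit. The step that the limit leaves unreadable from compound 2 to compound 4 is thus expected to show nothing beyond the scatter. Compound 4 is estimated at 80000 nM, within a range of 20000 nM to 300000 nM, most likely reported as a limit again.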

Compound 4, half-maximal inhibitory concentration: > 50000 nM
Compound 4 gave a limit, no number; the forecaster's own chance of this, stated with the estimate: 85%; the middle value is on the limit's open side.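

Compound 1, compound 2 and compound 4 each give only a limit in this assay, so neither the step from compound 2 to compound 4 nor the step from compound 1 to compound 4 can be read: the limit of > 50000 nM in this assay, at which 4 of the 4 values shown sit.

Which change to the shared core, if any, would give a compound an actual number in this assay stays open.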